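This account rests on a few compounds, and the source may have more. Where it says the series, first, only, none or still open, it means among the compounds named here.

Compound 1 `COc1cc(-c2nnc(SCC(=O)c3ccc(Br)cc3)n2N)cc(OC)c1OC`, measured in a functional assay on HepG2 cells (Homo sapiens) for antiproliferative activity, read by MTT assay, with a stated time of 48 h (a lower number here means a stronger inhibitor, a higher number a weaker inhibitor), gives 92500 nM.
Compound 2 `COc1cc(-c2nnc(SCC(=O)c3ccc(F)cc3)n2N)cc(OC)c1OC`, in this assay, gives 90400 nM.
Compound 3 `COc1cc(-c2nnc(SCC(=O)c3ccc(F)c(F)c3)n2N)cc(OC)c1OC` reaches only a limit in this assay, reported as > 100000 nM.

Among the two numbers shown, compound 1 carries the higher one, with compound 2 nearest to it; the step from compound 1 to compound 2 is a 1.0-fold lower number from compound 1 to compound 2 (0.01 log units; within the scatter), a change within the scatter. The third value is a limit: compound 3 sits at the limit of > 100000 nM in this assay, at which 1 of the 3 values shown sits. The steps reaching it are an at least 1.0-fold higher number from compound 1 to compound 3 (0.03 log units; that floor lies within the scatter) and an at least 1.1-fold higher number from compound 2 to compound 3 (0.04 log units; that floor lies within the scatter), both floors that lie within the scatter, so none of the halogen exchanges moved the number in a way that can be read.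

Compound 4 `COc1cc(-c2nnc(SCC(=O)Nc3ccccc3)n2N)cc(OC)c1OC` differs from compound 1 by anilino in place of 4-bromophenyl on a carbonyl carbon. Among the measured compounds shown here, no measured step touches this change; the three halogen steps only show that this series stayed near the same weak level throughout. Compound 4 is therefore expected to stay in that range, with a step of a 1.0-fold higher number from compound 1 to compound 4 (0.01 log units; within the scatter). The estimate for compound 4 is 95000 nM, between 40000 nM and 250000 nM.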

Compound 4, half-maximal inhibitory concentration: 49900 nM
Estimate against measurement, compound 4: 1.9-fold (0.28 log units) above; the range from low to high includes it.
By their numbers in this assay, from the lowest: compounds 4, 2 and 1 (each within the scatter of the next). At a limit, above all of these: compound 3.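

The earlier steps shown here exchanged only halogens on a phenyl ring, whereas anilino changes the link to the carbonyl carbon and brings in a hydrogen-bond donor that 4-bromophenyl lacks. Even this larger change stays within the scatter, with a 1.9-fold lower number from compound 1 to compound 4 (0.27 log units; within the scatter) and a 1.8-fold lower number from compound 2 to compound 4 (0.26 log units; within the scatter), so the position has so far tolerated it without a readable gain. Against compound 3 the step is only a floor, an at least 2.0-fold lower number from compound 3 to compound 4 (0.30 log units; that floor lies within the scatter), and it cannot be read as a change.

Compound 3 remains a limit, not a number: the limit of > 100000 nM in this assay, at which 1 of the 4 values shown sits.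

The compounds shown leave open whether a morpholine amide or a carboxylic acid in this place would move the number beyond the scatter. They also leave open whether a chloro or methoxy group on the anilino ring would do so.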